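The source may report more compounds than this note shows. Statements on the series, on what has been measured and on what is new or still open speak of the compounds shown alone.

Compound 1, `COc1ccccc1CNc1ncnc2c1ncn2[C@@H]1O[C@H](CO)[C@@H](O)[C@H]1O`, carries a 2-methoxybenzyl group on the shared core. In a functional assay on G-361 cells (Homo sapiens) for antiproliferative activity, with a stated time of 72 h (on this read-out lower numbers stand for stronger inhibition and higher numbers for weaker inhibition), compound 1 gives only a limit of the assay, > 166000 nM. Compound 3, `COc1cc(CNc2ncnc3c2ncn3[C@@H]2O[C@H](CO)[C@@H](O)[C@H]2O)cc(OC)c1O`, also gives only a limit in this assay, > 166000 nM. For compound 2, `COc1ccc(CNc2ncnc3c2ncn3C2OC(CO)[C@@H](O)[C@H]2O)c(O)c1`, this assay shows "not determined" (no result reported). So far, then, the picture is the limit of > 166000 nM in this assay, at which 2 of the 3 values shown sit, with no single number anywhere. Compound 4, `Cc1cccc(CNc2ncnc3c2ncn3[C@@H]2O[C@H](CO)[C@@H](O)[C@H]2O)c1O`, differs from compound 1 in one place: 2-hydroxy-3-methylphenyl in place of 2-methoxyphenyl on a saturated chain carbon bound to a nitrogen on an aromatic ring. Among the compounds with values here, no step between two measured compounds is available, so the expectation rests on compound 1 and compound 3 both sitting at the limit. The expected step is a step that the limit leaves unreadable from compound 1 to compound 4, that is, none beyond the scatter. Compound 4 is therefore estimated at 200000 nM, within a range from 80000 nM to 500000 nM.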

Compound 4, half-maximal inhibitory concentration: > 166000 nM
Compound 4 ended at the assay's limit; the forecaster's own chance of this, stated with the estimate: 80%; the middle value does not contradict the limit.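

The change from compound 1 to compound 4 cannot be sized in this assay, because both compounds give only a limit, not a number: the limit of > 166000 nM in this assay, at which 3 of the 4 values shown sit. The compounds shown leave open which group on the shared core, if any, would give a readable number.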